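The compounds below may be only part of what the source reports. "The series", "measured", "known", "first", "only" and "open" are said of these compounds alone.

Measured so far:
- compound 1 `O=C(NCCNS(=O)(=O)c1ccc(-c2ccccc2OCc2ccccc2)s1)Nc1cccc([N+](=O)[O-])c1`: 2800 nM
- compound 2 `Cc1cc(C)cc(NC(=O)NCCNS(=O)(=O)c2ccc(-c3ccccc3OCc3ccccc3)s2)c1`: 2200 nM

In a functional assay on HL-60 cells (Homo sapiens) for inhibition, read by CCK-8 assay, with a stated time of 48 h (on this read-out higher numbers stand for weaker inhibition and lower numbers for stronger inhibition), compound 2 stands at 2200 nM, within the scatter of compound 1 at 2800 nM, so neither compound ranks ahead of the other. The next analogue is compound 3 `O=C(NCCNS(=O)(=O)c1ccc(-c2ccccc2OCc2ccccc2)s1)Nc1cc(Cl)cc(Cl)c1`, which carries 3,5-dichlorophenyl in place of 3,5-dimethylphenyl on an amide-type nitrogen.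

For the measured compounds named here, only one measured step bears on this change. At the same place, 3,5-dimethylphenyl replaced 3-nitrophenyl, giving a 1.3-fold lower number from compound 1 to compound 2 (0.10 log units; within the scatter), a step within the scatter. This single step is thin evidence, but it gives no reason to expect a large shift. In this assay, the expected result is a 1.2-fold lower number from compound 2 to compound 3 (0.09 log units; within the scatter), with no clear direction and no step beyond the scatter. The estimated value for compound 3 is 1800 nM, with an expected range of 700 nM to 4500 nM.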

Compound 3, half-maximal inhibitory concentration: 11700 nM
Beside the measured number, compound 3's estimate is 6.5-fold (0.81 log units) below it; measured number outside the range, above it.
By their numbers in this assay, from the lowest: compounds 2 and 1 (each within the scatter of the next); then compound 3.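

In this assay the aryl group on an amide-type nitrogen is not a free choice: a 5.3-fold higher number from compound 2 to compound 3 (0.73 log units; beyond the scatter) follows 3,5-dichlorophenyl in place of 3,5-dimethylphenyl, and a 4.2-fold higher number from compound 1 to compound 3 (0.62 log units; beyond the scatter) follows the same group in place of 3-nitrophenyl. Compound 1 and compound 2 sat within the scatter of each other and hinted at a flat position, whereas compound 3 separates from both, even though 3,5-dichlorophenyl and 3,5-dimethylphenyl match in heavy-atom count and in hydrogen-bond donors and acceptors. No available measurement accounts for this shift.

From the compounds shown here alone, whether the shift follows chlorine itself or the substitution pattern of 3,5-dichlorophenyl stays open, and other aryl groups at this place would separate the two. Also open, going by these compounds, is how this position responds to a ring carrying an amine or a carboxylic acid.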